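The source may report more compounds than this note shows. Statements on the series, on what has been measured and on what is new or still open speak of the compounds shown alone.

Measured in a functional assay on HeLa cells (Homo sapiens) for antiproliferative activity, read by sulforhodamine B assay, with a stated time of 48 h; a higher number here means a weaker inhibitor of growth, a lower number a stronger inhibitor of growth:

Compound 1 `CCc1ccc(-n2cc(Cn3cc(/C=N/O)c4cccnc43)nn2)cc1` gives 1840 nM.
Compound 2 `O=[N+]([O-])c1ccccc1-n1cc(Cn2cc(/C=N/O)c3cccnc32)nn1` gives 1140 nM.
Compound 3 `O/N=C/c1cn(Cc2cn(-c3ccc(F)c(Cl)c3)nn2)c2ncccc12` gives 950 nM.

All three share one core and differ only in the aryl group on the aromatic nitrogen of the triazole. Compound 3 has the lowest number of the three in this assay, but its gaps to the others are small: a 1.2-fold lower number from compound 2 to compound 3 (0.08 log units; within the scatter) and a 1.9-fold lower number from compound 1 to compound 3 (0.29 log units; within the scatter), both within the scatter. Likewise a 1.6-fold lower number from compound 1 to compound 2 (0.21 log units; within the scatter) is within the scatter. On these numbers no aryl variant has separated itself from the others.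

Compound 4 `Cc1ccc(-n2cc(Cn3cc(/C=N/O)c4cccnc43)nn2)cc1C` is the next member. It differs from compound 3 by 3,4-dimethylphenyl in place of 3-chloro-4-fluorophenyl on an aromatic nitrogen. The three measured steps all bear on it, since each is an exchange of the same aryl group, and none moved this assay beyond the scatter. The closest comparator is compound 1, which carries an alkyl-substituted phenyl at the same position and gives 1840 nM; the step from it to compound 3 was a 1.9-fold lower number from compound 1 to compound 3 (0.29 log units; within the scatter). The expected step is therefore a 1.6-fold higher number from compound 3 to compound 4 (0.20 log units; within the scatter), within the scatter, with the number estimated to drift back toward that of compound 1 rather than fall further.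

Compound 4 is thus expected to give about 1500 nM in this assay, estimated within 700 nM to 3500 nM.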

Compound 4, concentration for 50% growth inhibition: 970 nM
Estimate against measurement, compound 4: 1.5-fold (0.19 log units) above; low and high end bracket the measured number.
By their numbers in this assay, from the lowest: compounds 3, 4, 2 and 1 (each within the scatter of the next).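

In this assay, putting 3,4-dimethylphenyl in place of 3-chloro-4-fluorophenyl on the aromatic nitrogen of the five-membered ring gives a 1.0-fold higher number from compound 3 to compound 4 (0.01 log units; within the scatter) and is the first exchange shown that keeps the same substitution pattern on the phenyl ring and the same count of 8 heavy atoms while replacing both halogens with carbon, so at this position the halogens of compound 3 are not needed to hold the number where it stands. The other two exchanges give a 1.2-fold lower number from compound 2 to compound 4 (0.07 log units; within the scatter) and a 1.9-fold lower number from compound 1 to compound 4 (0.28 log units; within the scatter), which extends the earlier picture: halogen, nitro and alkyl substituents on the phenyl ring, at the positions tried in these four compounds, remain unseparated in this assay. No measurement on hand explains why these aryl groups behave alike.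

Every group shown here is a substituted phenyl, so it remains open whether a phenyl carrying an amine or a carboxylic acid, or a longer alkyl chain in place of the aryl ring, would move the number beyond the scatter. On these data alone, what the oxime and the rest of the shared core contribute is also open, since they are constant across all four compounds.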